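Moving the Methyl on the Indole of Compound 2

This account rests on a few compounds, and the source may have more. Where it says the series, first, only, none or still open, it means among the compounds named here.

Compound 1, `Cc1nc2ccccc2n1CCCCN1CCN(C(c2ccccc2)c2ccccc2)CC1`: 850 nM
Compound 2, `Cc1ccc2ccn(CCCCN3CCN(C(c4ccccc4)c4ccccc4)CC3)c2c1`: 6500 nM

Among the compounds with values here, in an assay on RPMI-8226 cells for antagonist activity at P2X purinoceptor 7 (Homo sapiens), read by calcium flux (a higher number here means a weaker inhibitor, a lower number a stronger inhibitor), compound 2 holds the highest, and so the weakest, of the two measured numbers; its only neighbour is compound 1, and the change between them gave a 7.6-fold higher number from compound 1 to compound 2 (0.88 log units; beyond the scatter). Compound 3, `Cc1cccc2ccn(CCCCN3CCN(C(c4ccccc4)c4ccccc4)CC3)c12`, differs from compound 2 by a group of 10 heavy atoms (9 carbon, 1 nitrogen; one five-membered aromatic ring with 1 hetero atom, one six-membered aromatic ring of carbon only) in place of a group of 10 heavy atoms (9 carbon, 1 nitrogen; one five-membered aromatic ring with 1 hetero atom, one six-membered aromatic ring of carbon only), on a saturated chain carbon, four bonds along the chain from an amine nitrogen in a ring. Within the data shown here, no measured step bears on this rearrangement, since the one known step exchanges a different pair of groups. Compound 3 is therefore expected to sit close to compound 2, with a step of a 1.1-fold lower number from compound 2 to compound 3 (0.03 log units; within the scatter), nothing beyond the scatter. The estimate for compound 3 is 6000 nM, ranging from 2000 nM to 20000 nM.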

Compound 3, half-maximal inhibitory concentration: 2300 nM
Compound 3: middle estimate off by 2.6-fold (0.42 log units), on the high side, and the stated range covers the measured number.
By their numbers in this assay, from the lowest: compound 1; then compound 3; then compound 2.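

In this assay the shift of the methyl to give 7-methyl-1H-indol-1-yl, with the same atoms joined differently, produced a 2.8-fold lower number from compound 2 to compound 3 (0.45 log units; beyond the scatter) and so shows that the methyl's place on the ring matters, even with no atom gained or lost. This group still falls short of 2-methyl-1H-benzimidazol-1-yl, as a 2.7-fold higher number from compound 1 to compound 3 (0.43 log units; beyond the scatter) shows across that exchange. No measurement shown here explains either step.

Open, as far as these compounds go, is how a chloro group in place of this methyl would compare. Also open, from the compounds shown here alone, is what a longer chain would do to the number.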